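Swapping a Cyclopentyl for a Chloropyrimidine on the Amide

This account rests on a few compounds, and the source may have more. Where it says the series, first, only, none or still open, it means among the compounds named here.

Compound 1, `Cc1nc(S(C)(=O)=O)ccc1Oc1ncnc(OC2CCN(C(=O)OC(C)(C)C#N)CC2)c1F`: 92.9 nM
Compound 2, `Cc1nc(S(C)(=O)=O)ccc1Oc1ncnc(OC2CCN(C(=O)SC(C)(C)C)CC2)c1F`: 4.83 nM
Compound 3, `Cc1nc(S(C)(=O)=O)ccc1Oc1ncnc(OC2CCN(C(=O)C3CCCC3)CC2)c1F`: 72.8 nM

All three were tested in a functional assay on isolated protein for inhibition of Glucose-dependent insulinotropic receptor (Homo sapiens), read by HTRF and cAMP accumulation; a lower number here means that less compound is needed, a higher number that more compound is needed for the effect. Compound 3 stands second highest of the three numbers; one step to it lies within the scatter, a 1.3-fold lower number from compound 1 to compound 3 (0.11 log units; within the scatter), while the other is large, a 15-fold higher number from compound 2 to compound 3 (1.18 log units; beyond the scatter). Compound 4, `Cc1nc(S(C)(=O)=O)ccc1Oc1ncnc(OC2CCN(C(=O)c3ncc(Cl)cn3)CC2)c1F`, differs from compound 3 in one place: 5-chloropyrimidin-2-yl in place of cyclopentyl on a carbonyl carbon. Both measured steps that end at compound 3 change a group on the same carbonyl carbon, but neither brings in an aromatic ring, and their sizes disagree, so they give no clear direction. Among the compounds with values here, with no close precedent, compound 4 is expected to stay near compound 3, and the step of a 1.2-fold lower number from compound 3 to compound 4 (0.08 log units; within the scatter) is expected to be small. The estimate for compound 4 is 60 nM, between 10 nM and 350 nM.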

Compound 4, half-maximal effective concentration: 6.12 nM
Estimate against measurement, compound 4: 9.8-fold (0.99 log units) above; measured number outside the range, below it.
By their numbers in this assay, from the lowest: compounds 2 and 4 (each within the scatter of the next); then compounds 3 and 1 (each within the scatter of the next).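

On this carbonyl carbon, an aromatic ring carrying hetero atoms can replace a carbon-only ring with a large effect: a 12-fold lower number from compound 3 to compound 4 (1.08 log units; beyond the scatter), and a 15-fold lower number from compound 1 to compound 4 (1.18 log units; beyond the scatter). The 5-chloropyrimidin-2-yl group also matches the (tert-butyl)sulfanyl group, with a 1.3-fold higher number from compound 2 to compound 4 (0.10 log units; within the scatter), so two very different groups here give similarly low numbers. No measured evidence explains this gain.

The compounds shown leave open whether the chlorine, the ring nitrogens or the aromatic ring itself carries the step. A plain phenyl ring or a pyrimidin-2-yl group without chlorine would help separate these.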